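The source may report more compounds than this note shows. Statements on the series, on what has been measured and on what is new or still open speak of the compounds shown alone.

- Compound 1 `COCC(C(=O)N1CCN(c2cccc(Cl)c2Cl)CC1)N1C(=O)CCC1=O`: 38 mg/kg
- Compound 2 `COC[C@@H](C(=O)N1CCN(c2ccc(C(F)(F)F)cc2)CC1)N1C(=O)CCC1=O`: 37.9 mg/kg
- Compound 3 `COC[C@H](C(=O)N1CCN(c2ccc(C(F)(F)F)cc2)CC1)N1C(=O)CCC1=O`: 21.1 mg/kg

In a functional assay on the whole organism (strain Swiss CD-1) with Mus musculus as the target, with a stated time of 2 h (a higher number here means that more compound is needed for the effect, a lower number that less compound is needed), compound 1, at 38 mg/kg, stands within the scatter of both compound 2 and compound 3. Compound 4 `COCC(C(=O)N1CCN(c2cccc(OC)c2)CC1)N1C(=O)CCC1=O` departs from compound 1 at a single place: 3-methoxyphenyl in place of 2,3-dichlorophenyl on an amine nitrogen in a ring.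

For the measured compounds named here, no measured step covers an exchange of this kind. The only one, a 1.8-fold lower number from compound 2 to compound 3 (0.25 log units; within the scatter), reflects the fact that compounds 2 and 3 differ only in the configuration as drawn and so bears on configuration, not on the group at the amine nitrogen. Some indirect guidance comes from compound 1 and compound 2, which carry different groups at that place yet give values within the scatter of each other. On this limited evidence, no step beyond the scatter is expected in this assay, and no direction is favoured. The expected step is a 1.1-fold lower number from compound 1 to compound 4 (0.04 log units; within the scatter). For compound 4 the estimated value is 35 mg/kg, with an expected range from 15 mg/kg to 80 mg/kg.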

Compound 4, dose for half-maximal effect: > 100 mg/kg
Compound 4 ended at the assay's limit (the forecaster's own chance of this, stated with the estimate: 10%); at least 2.8-fold (0.45 log units) between middle value and limit.
By their numbers in this assay, from the lowest: compounds 3, 2 and 1 (each within the scatter of the next). At a limit, above all of these: compound 4.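

In this assay, the exchange of 2,3-dichlorophenyl for 3-methoxyphenyl on the amine nitrogen in the ring gives an at least 2.6-fold higher number from compound 1 to compound 4 (0.42 log units; beyond the scatter), the first step among the compounds shown that lies beyond the scatter. For the compounds shown here, the group at this place therefore does not leave the number unchanged, something the only earlier step could not show, as it bears on configuration alone: the fact that compounds 2 and 3 differ only in the configuration as drawn. Compound 4 has no exact value, only a limit of the assay: the limit of > 100 mg/kg in this assay, at which 1 of the 4 values shown sits.

The compounds shown do not tell whether the departure of the two chlorine atoms or the arrival of the methoxy group carries the step. Also open, as far as these compounds go, is where a plain phenyl, a 3-chlorophenyl or a 3-hydroxyphenyl on the same nitrogen would stand in this assay.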